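Adding a Chloro Group to Compound 1

The source may hold more compounds than are shown below. What is called first, only, known or untested is meant among the compounds shown, and "the series" means these compounds.

In a functional assay on J774 cells (Mus musculus) for cytotoxicity, read by resazurin assay (a higher number here means a weaker inhibitor, a lower number a stronger inhibitor), compound 1 `OCCCCCC(O)c1ccc(-c2ccc(F)cc2)cc1` gives 18000 nM, while compound 2 `Cc1ccc(-c2ccc(C(O)CCCCCO)cc2)cc1` gives 22000 nM. For the measured compounds named here, compound 1 therefore stands within the scatter of its only measured neighbour, and the two cannot be ranked. Compound 3 `OCCCCCC(O)c1ccc(-c2ccc(F)cc2)cc1Cl` has chloro in place of hydrogen on an aromatic carbon. The chloro lies ortho to a group of 8 heavy atoms and meta to a 4-fluorophenyl group. Going by the values given here, no measured step changes that place, so the evidence is indirect. Among the compounds with values here, the one available step, with methyl in place of fluoro on an aromatic carbon, is a 1.2-fold higher number from compound 1 to compound 2 (0.09 log units; within the scatter). On that slender basis, no change beyond the scatter is expected in this assay. The expected change is a 1.2-fold lower number from compound 1 to compound 3 (0.08 log units; within the scatter). For compound 3 the estimated value is 15000 nM, with an expected range of 7000 nM to 30000 nM.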

Compound 3, half-maximal inhibitory concentration: 8000 nM
The estimate for compound 3 lay 1.9-fold (0.27 log units) above the measured number; low and high end bracket the measured number.
By their numbers in this assay, from the lowest: compound 3; then compounds 1 and 2 (each within the scatter of the next).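

Chloro in place of hydrogen on this aromatic carbon, ortho to a group of 8 heavy atoms and meta to a 4-fluorophenyl group, produces the first step beyond the scatter in this assay: a 2.3-fold lower number from compound 1 to compound 3 (0.35 log units; beyond the scatter). The only earlier step, a 1.2-fold higher number from compound 1 to compound 2 (0.09 log units; within the scatter), stayed within the scatter, so this is the one place among those shown where a change moves the number, and the move is modest. Nothing measured on these compounds explains the step.

Going by these compounds, whether the step belongs to chloro itself or would also appear with another group on this carbon, such as methyl, methoxy or a carboxylic acid, remains open. Also open, on these data alone, is whether chloro at this place gives a similar step when methyl replaces fluoro, as in compound 2, or when the chain is longer.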